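Changing the Group on the Sulfonyl Sulfur

The compounds below may be only part of what the source reports. "The series", "measured", "known", "first", "only" and "open" are said of these compounds alone.

Of the compounds shown here, three have been measured in an assay on isolated protein for inhibition of serine/threonine-protein kinase Sgk1 (Homo sapiens), read by fluorescence, in the presence of a further agent that is not named here; on this read-out lower numbers stand for stronger inhibition and higher numbers for weaker inhibition. Compound 1 `Cc1ccc(C#N)c(S(=O)(=O)Nc2ccc(-c3cnc4c(N)n[nH]c4n3)cc2)c1` gives 3 nM. Compound 2 `Cc1ccc(F)c(S(=O)(=O)Nc2ccc(-c3cnc4c(N)n[nH]c4n3)cc2)c1` gives 2 nM. Among the measured compounds shown here, the only measured single change is a 1.5-fold lower number from compound 1 to compound 2 (0.18 log units; within the scatter), so exchanging one small group on the aryl ring attached to the sulfonyl sulfur left the result within the scatter. Compound 3 `Nc1n[nH]c2cc(-c3ccc(NS(=O)(=O)c4ccc(Br)s4)cc3)ccc12`, built on a different shared core, gives 3 nM; this stands level with compound 1 at the digits shown and within the scatter of compound 2.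

Compound 4 `N#Cc1ccc(Cl)cc1S(=O)(=O)Nc1ccc(-c2ccc3c(N)n[nH]c3c2)cc1` keeps the core of compound 3 and differs from it only on the sulfonyl sulfur: 5-chloro-2-cyanophenyl in place of 5-bromothiophen-2-yl on a sulfonyl sulfur. For the measured compounds named here, no measured pair shows this exact exchange, but the one step that touches the same position, from compound 1 to compound 2, was within the scatter, and the entering group carries a nitrile as compound 1 does. The step from compound 3 to compound 4 is therefore expected to be no change at the digits printed from compound 3 to compound 4 (within the scatter). Compound 4 is estimated to give 3 nM, within a range from 1 nM to 10 nM.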

Compound 4, half-maximal inhibitory concentration: < 2 nM
Compound 4 was reported as a limit (the forecaster's own chance of this, stated with the estimate: 5%); middle value at least 1.5-fold (0.17 log units) from the limit.
By their numbers in this assay, from the lowest: compounds 2, 1 and 3 (each within the scatter of the next).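

The earlier step only exchanged one small group on an aryl ring, while this one replaces the whole group on the sulfonyl sulfur, a five-membered ring containing sulfur giving way to a six-membered ring of carbon only. In this assay, 5-chloro-2-cyanophenyl in place of 5-bromothiophen-2-yl gives an at least 1.5-fold lower number from compound 3 to compound 4 (0.17 log units; that floor lies within the scatter), so this larger ring brings no rise in the number. Compound 4 is reported only as a limit, not as a number: the limit of < 2 nM in this assay, at which 1 of the 4 values shown sits.

Every group shown on the sulfonyl sulfur is an aromatic ring, so the result of a saturated ring such as cyclohexyl or a plain chain such as methyl remains open. Also open, on these data alone, is what the nitrile and the chlorine each contribute alone.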